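Swapping 1-hydroxy-1-methylethyl for 2H-tetrazol-5-yl on a shared core

This account rests on a few compounds, and the source may have more. Where it says the series, first, only, none or still open, it means among the compounds named here.

Measured in a functional assay for inhibition, with Homo sapiens as the target (on this read-out higher numbers stand for weaker inhibition and lower numbers for stronger inhibition), so far:
compound 1 (`CC(O)c1cc(-c2ccccc2)c2ccc(OCc3cccc(C4(O)CCOCC4)c3)cc2c1`) with 28 nM
compound 2 (`CC(C)(O)c1cc(-c2ccccc2)c2ccc(OCc3cccc(C4(O)CCOCC4)c3)cc2c1`) with 59 nM
compound 3 (`O=C(O)c1cc(-c2ccccc2)c2ccc(OCc3cccc(C4(O)CCOCC4)c3)cc2c1`) with 190 nM

Compound 2 holds the second highest of these three numbers, with compound 1 lower and compound 3 higher, both beyond the scatter. Compound 4 (`OC1(c2cccc(COc3ccc4c(-c5ccccc5)cc(-c5nn[nH]n5)cc4c3)c2)CCOCC1`) shares the core of compound 2 and carries 2H-tetrazol-5-yl in place of 1-hydroxy-1-methylethyl on an aromatic carbon. Among the measured compounds shown here, no compound with this group has been measured. The nearest evidence is the swap of the same leaving group for carboxy, which gave a 3.2-fold higher number from compound 2 to compound 3 (0.51 log units; beyond the scatter) in this assay as a modest step. The swap to carboxy from 1-hydroxyethyl gave a 6.8-fold higher number from compound 1 to compound 3 (0.83 log units; beyond the scatter) in the same direction. A modest step toward a higher number is therefore expected, of about the size seen with compound 3. The estimated step is a 2.5-fold higher number from compound 2 to compound 4 (0.41 log units; beyond the scatter) on this reasoning. Compound 4 is estimated at 150 nM in this assay (expected range 45 nM to 500 nM)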

Compound 4, half-maximal inhibitory concentration: > 700 nM
Compound 4: only a limit was reported; the forecaster's own chance of this, stated with the estimate: 2%; at least 4.6-fold (0.66 log units) between middle value and limit.
By their numbers in this assay, from the lowest: compound 1; then compound 2; then compound 3. At a limit, above all of these: compound 4.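

Compound 4 is reported only as a limit, not as a number: the limit of > 700 nM in this assay, at which 1 of the 4 values shown sits. Even so, the change on this aromatic carbon gives an at least 11-fold higher number from compound 2 to compound 4 (1.07 log units; beyond the scatter) and an at least 25-fold higher number from compound 1 to compound 4 (1.39 log units; beyond the scatter), both large, whereas the earlier compounds showed only modest steps at this position. 2H-tetrazol-5-yl also stands apart from carboxy, with an at least 3.6-fold higher number from compound 3 to compound 4 (0.56 log units; beyond the scatter), so at this position the two groups cannot be treated as interchangeable, and the order of the four compounds runs from the 1-hydroxyethyl compound 1 up to the tetrazole compound 4.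

Going by these compounds, how far compound 4 lies past its limit stays unknown, so the full size of these steps cannot be given. The compounds shown also leave open how a primary amide, a hydroxymethyl group or an oxadiazole ring on this carbon would read out.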